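Swapping methyl for chloro on the aryl ring

The source may hold more compounds than are shown below. What is called first, only, known or untested is meant among the compounds shown, and "the series" means these compounds.

Of the compounds shown here, two of one shared core have been measured. Compound 1 `O=C1c2ccc(C#Cc3cccc(Cl)c3)nc2CCN1C1CCCC1` gives 33 nM in a functional assay on HEK293 cells for positive allosteric modulation of metabotropic glutamate receptor 5 (Homo sapiens), read by FLIPR and calcium flux; a lower number here means that less compound is needed, a higher number that more compound is needed for the effect. Compound 2 `Cc1cccc(C#Cc2ccc3c(n2)CCN(C2CCCCC2)C3=O)c1` gives 36 nM in this assay; this is the highest of the two numbers, but its nearest neighbour is compound 1, and the two values lie within the scatter of each other, so nothing can be read as a difference between them. Compound 3 `O=C1c2ccc(C#Cc3cccc(Cl)c3)nc2CCN1C1CCCCC1` has not yet been measured in this assay. It differs from compound 2 in one place: chloro in place of methyl on an aromatic carbon. For the measured compounds named here, no measured pair shows this exact exchange alone, so there is no step to lean on. Compound 1, which carries the chloro group and gives 33 nM, sits at the same level as compound 2. The step from compound 2 to compound 3 is therefore expected to be small, a 1.2-fold lower number from compound 2 to compound 3 (0.08 log units; within the scatter), in no particular direction beyond the scatter. Compound 3 is expected to give 30 nM, with a likely range from 12 nM to 75 nM.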

Compound 3, half-maximal effective concentration: 171 nM
The estimate for compound 3 lay 5.7-fold (0.76 log units) below the measured number; measured number outside the range, above it.
By their numbers in this assay, from the lowest: compounds 1 and 2 (each within the scatter of the next); then compound 3.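

In this assay, chloro in place of methyl on this aromatic carbon is not a neutral exchange when cyclohexyl sits on the amide nitrogen: the change gives a 4.8-fold higher number from compound 2 to compound 3 (0.68 log units; beyond the scatter) and so calls for more compound. The group on that nitrogen also matters. With the 3-chlorophenyl group held fixed, cyclohexyl in place of cyclopentyl gives a 5.2-fold higher number from compound 1 to compound 3 (0.71 log units; beyond the scatter) in the same direction. Nothing available here bears on why either step occurs.

Still open, as far as these compounds go, is whether chloro and methyl would also differ with cyclopentyl on the amide nitrogen, which would show whether the two changes depend on each other. Also open, from the compounds shown here alone, is how fluoro, methoxy or a nitrile would read on this aromatic carbon, and how cyclobutyl or an open isopropyl group would read on the nitrogen.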